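Trimming a Cyclohexyl from a Piperazinyl Tetrahydroisoquinoline Series

The source may hold more compounds than are shown below. What is called first, only, known or untested is meant among the compounds shown, and "the series" means these compounds.

Compound 1 `CN(C[C@@H]1Cc2c(cccc2N2CCNCC2)CN1)[C@H]1CCCc2cccnc21`: 313 nM
Compound 2 `C[C@@H]1CN(c2cccc3c2C[C@H](CN(C)[C@H]2CCCc4cccnc42)NC3)C[C@H](C)N1C`: 14.1 nM
Compound 3 `c1cnc2c(c1)CCC[C@@H]2N(CC1CCCCC1)C[C@H]1Cc2c(cccc2N2CCNCC2)CN1`: 715 nM

In a functional assay on CCRF-CEM cells for antagonist activity at C-X-C chemokine receptor type 4 (Homo sapiens), read by calcium flux, with stated times of 25 min and 90 s (a lower number here means a stronger inhibitor, a higher number a weaker inhibitor), compound 3 gives 715 nM, the highest number of the three measured compounds. Its nearest neighbour is compound 1, whose 313 nM lies beyond the scatter, while compound 2 stands furthest away at 14.1 nM.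

Compound 4 `CN(C[C@H]1Cc2c(cccc2N2CCNCC2)CN1)[C@H]1CCCc2cccnc21` has not yet been measured. It differs from compound 3 by hydrogen in place of cyclohexyl on a saturated chain carbon bound to an amine nitrogen. For the measured compounds named here, no measured pair shows this change alone, so the size of the step is open. Compound 4 is expected to give a modestly lower number than compound 3, a step of a 1.8-fold lower number from compound 3 to compound 4 (0.25 log units; within the scatter) in this assay. Compound 4 is therefore estimated at 400 nM, within a range of 120 nM to 1500 nM.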

Compound 4, half-maximal inhibitory concentration: 6.08 nM
Estimate against measurement, compound 4: 66-fold (1.82 log units) above; the measured number lies below the stated range.
By their numbers in this assay, from the lowest: compound 4; then compound 2; then compound 1; then compound 3.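

In this assay, the cyclohexyl carries a heavy penalty: hydrogen in its place gives a 120-fold lower number from compound 3 to compound 4 (2.07 log units; beyond the scatter). Configuration at the saturated ring carbon also proves decisive, with a 51-fold lower number from compound 1 to compound 4 (1.71 log units; beyond the scatter), and nothing else separates this pair: the fact that compounds 1 and 4 differ only in the configuration as drawn. The piperazine substitution counts for much less, as piperazin-1-yl in place of 3,4,5-trimethylpiperazin-1-yl gives only a 2.3-fold lower number from compound 2 to compound 4 (0.37 log units; beyond the scatter).

From the compounds shown here alone, whether an ethyl or propyl group in place of the cyclohexyl would stay close to compound 4 remains open. So does the effect of a single methyl on the piperazine.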